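Swapping the aryl group on the shared core

The source may report more compounds than this note shows. Statements on the series, on what has been measured and on what is new or still open speak of the compounds shown alone.

Measured compounds:
compound 1, `COc1ccc(-n2cnc3c(NC(C4CC4)C4CC4)nc(C)nc32)c(C)c1`, 47 nM
compound 2, `COc1ccc(-n2c(C)nc3c(NC(C4CC4)C4CC4)nc(C)nc32)c(C)c1`, 14 nM
compound 3, `COc1ccc(-n2c(CC3CC3)nc3c(NC(C4CC4)C4CC4)nc(C)nc32)cc1`, 308 nM

All three were tested in a functional assay on CHO cells for antagonist activity at corticotropin-releasing factor receptor 1 (Homo sapiens), read by cAMP accumulation; on this read-out higher numbers stand for weaker inhibition and lower numbers for stronger inhibition. Compound 2 gives the lowest of the three numbers; its nearest neighbour is compound 1, and compound 3 stands furthest away. Within the data shown here, the one single-point step among them, a 3.4-fold lower number from compound 1 to compound 2 (0.53 log units; beyond the scatter), concerns a methyl on an aromatic carbon of the core and leaves the aryl group untouched. Compound 3 differs from compound 2 in two places at once, so its much higher number cannot be assigned to either change alone.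

Compound 4, `Cc1nc(NC(C2CC2)C2CC2)c2nc(C)n(-c3ccc(F)cc3)c2n1`, has not been measured. It differs from compound 2 by 4-fluorophenyl in place of 4-methoxy-2-methylphenyl on an aromatic nitrogen. Among the measured compounds shown here, no measured step concerns this aryl group, so the expectation rests on thin ground. Compound 4 is expected to show a 4.3-fold higher number from compound 2 to compound 4 (0.63 log units; beyond the scatter), a rise in this assay. The estimate for compound 4 is 60 nM, within 15 nM to 300 nM.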

Compound 4, inhibition constant: 91 nM
Compound 4: the middle estimate sits 1.5-fold (0.18 log units) below what was measured; measured number inside the range.
By their numbers in this assay, from the lowest: compound 2; then compounds 1 and 4 (each within the scatter of the next); then compound 3.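

Among these compounds, the aryl group on the aromatic nitrogen, which no earlier single-point step had touched, proves to matter in this assay: the change to 4-fluorophenyl gives a 6.5-fold higher number from compound 2 to compound 4 (0.81 log units; beyond the scatter). That one swap removes the methoxy and the aryl methyl and adds the fluorine, so the step cannot be divided among these three changes. No measurement at hand explains the rise.

On these data alone, it remains open whether an aryl group keeping only the methoxy or only the methyl would stay close to compound 2 or move towards compound 4. The compounds shown also leave open how this position would respond to an aryl group carrying a dimethylamino group, or to a pyridine ring in place of the benzene ring.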